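Sulfone series: working notes on the amine substituent

The source may hold more compounds than are shown below. What is called first, only, known or untested is meant among the compounds shown, and "the series" means these compounds.

Measured so far:
- compound 1 `Cn1c(=O)c(S(=O)(=O)Cc2ccc(F)cc2)cc2cnc(Nc3ccc4[nH]ccc4c3)nc21` — 30000 nM
- compound 2 `Cn1c(=O)c(S(=O)(=O)c2ccc(F)cc2F)cc2cnc(Nc3ccc4cccc(O)c4n3)nc21` — 5000 nM
- compound 3 `Cn1ccc2cc(Nc3ncc4cc(S(=O)(=O)c5ccc(Cl)cc5Cl)c(=O)n(C)c4n3)ccc21` — 750 nM

Three compounds on a shared core have been run in a functional assay on DU-145 cells (Homo sapiens) for inhibition, read by trypan blue exclusion, with a stated time of 72 h; on this read-out lower numbers stand for stronger inhibition and higher numbers for weaker inhibition. Compound 3 gives 750 nM, compound 2 gives 5000 nM and compound 1 gives 30000 nM. Compound 2 stands second highest of the three numbers: its nearest neighbour is compound 1, whose number lies higher by a gap beyond the scatter, and compound 3 lies lower by a gap that is also beyond the scatter. No two of the measured compounds differ in a single place, so no clean step can be read from the measured set.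

Compound 4 `Cn1c(=O)c(S(=O)(=O)c2ccc(F)cc2F)cc2cnc(Nc3ccncn3)nc21` is not yet measured. Against compound 2 the change is pyrimidin-4-yl in place of 8-hydroxyquinolin-2-yl on a nitrogen on an aromatic ring. The entering group is the smaller of the two and carries 0 hydrogen-bond donors, where the leaving group carried 1. For the measured compounds named here, no measured pair tests this amine position, so the expectation rests on the change itself. The step from compound 2 to compound 4 is expected to be a rise in the number, a 3.0-fold higher number from compound 2 to compound 4 (0.48 log units; beyond the scatter), beyond the scatter, though with wide uncertainty. Compound 4 is estimated at 15000 nM, with a range from 4000 nM to 50000 nM.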

Compound 4, half-maximal inhibitory concentration: 50000 nM
Compound 4: the middle estimate sits 3.3-fold (0.52 log units) below what was measured; measured number inside the range.
By their numbers in this assay, from the lowest: compound 3; then compound 2; then compounds 1 and 4 (each within the scatter of the next).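

In this assay, the amine substituent now has its first clean step: pyrimidin-4-yl in place of 8-hydroxyquinolin-2-yl on a nitrogen on an aromatic ring gives a 10-fold higher number from compound 2 to compound 4 (1.00 log units; beyond the scatter), the size of the step being rated modest. Compounds 1, 2 and 3 differ in more than one place and could not separate this substituent from the rest of the molecule, whereas this pair shares its sulfone and core, so the amine substituent alone is shown to move the number beyond the scatter. The step removes one ring and the hydrogen-bond donor together, and nothing available indicates which of these changes, if either, accounts for the result.

From the compounds shown here alone, it remains open whether a quinolin-2-yl group without the hydroxyl, or with a methoxy group in its place, would stay close to compound 2 or move towards compound 4. Also open, going by these compounds, are whether pyrimidin-4-yl carrying a small amine or a morpholine would change the number, and whether this same exchange gives a similar step with the sulfone of compound 3.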